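The source may hold more compounds than are shown below. What is called first, only, known or untested is meant among the compounds shown, and "the series" means these compounds.

Measured compounds in a functional assay on AGS cells (Homo sapiens) for antiproliferative activity, read by CCK-8 assay, with a stated time of 72 h; a higher number here means a weaker inhibitor, a lower number a stronger inhibitor:
- compound 1 `O=C(Nc1ccc(-c2cnc3cc(C4=CCN(C5COC5)CC4)ccn23)cc1)c1ccc([N+](=O)[O-])o1`: 790 nM
- compound 2 `CC1(O)CCN(c2ccn3c(-c4ccc(NC(=O)c5ccc([N+](=O)[O-])o5)cc4)cnc3c2)CC1`: 1530 nM
- compound 3 `CN1CCCN(c2ccn3c(-c4ccc(NC(=O)c5ccc([N+](=O)[O-])o5)cc4)cnc3c2)CC1`: 2700 nM

Compound 3 gives the highest number of the three. Its step to compound 2 is within the scatter, as a 1.8-fold higher number from compound 2 to compound 3 (0.25 log units; within the scatter) shows; only against compound 1 is there a modest separation, a 3.4-fold higher number from compound 1 to compound 3 (0.53 log units; beyond the scatter).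

The step to compound 4 `COc1ccn2c(-c3ccc(NC(=O)c4ccc([N+](=O)[O-])o4)cc3)cnc2c1` is methoxy in place of 4-methyl-1,4-diazepan-1-yl on an aromatic carbon. Going by the values given here, every measured step at this position so far has swapped one ring group for another ring group: a 1.9-fold higher number from compound 1 to compound 2 (0.29 log units; within the scatter), a 3.4-fold higher number from compound 1 to compound 3 (0.53 log units; beyond the scatter) and a 1.8-fold higher number from compound 2 to compound 3 (0.25 log units; within the scatter). Each of these steps was modest or within the scatter, and replacing the group present in compound 1 with either alternative gave a higher number. The change to compound 4 removes the ring altogether and has no measured parallel in the series, so the comparison rests on the direction seen in these three steps rather than on a matching case.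

On that basis compound 4 is expected to move somewhat further in the same direction, with a 1.7-fold higher number from compound 3 to compound 4 (0.22 log units; within the scatter) as the estimated step, though a result within the scatter of compound 3 would not be surprising. The estimated value for compound 4 in this assay is 4500 nM, with a range of 1500 nM to 14000 nM.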

Compound 4, half-maximal inhibitory concentration: 720 nM
Beside the measured number, compound 4's estimate is 6.3-fold (0.80 log units) above it; measured number below the stated range.
By their numbers in this assay, from the lowest: compounds 4, 1, 2 and 3 (each within the scatter of the next, the first and the last beyond it).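

In this assay the ring groups no longer set the limit at this position, opposite the ring nitrogen: methoxy, with no ring at all, separates clearly from 4-methyl-1,4-diazepan-1-yl (a 3.8-fold lower number from compound 3 to compound 4 (0.57 log units; beyond the scatter)) and from 4-hydroxy-4-methylpiperidin-1-yl (a 2.1-fold lower number from compound 2 to compound 4 (0.33 log units; beyond the scatter)), against the rise seen among the earlier ring groups. It also cannot be told apart from the larger two-ring group of compound 1 (a 1.1-fold lower number from compound 1 to compound 4 (0.04 log units; within the scatter)), so across these four compounds the number does not follow the size of the group, and a large group is not needed to reach the low end of the series. No measurement is available that would account for these differences, so the numbers stand here as a description only.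

Still open, as far as these compounds go, is whether methoxy is a special case or whether other small groups without a ring, such as ethoxy, a hydroxyl or a primary amine, sit with compound 4 rather than with compound 3. A longer chain, such as 2-methoxyethoxy, or a morpholine ring would also show whether the gap between compound 4 and compound 3 follows the ring, the second nitrogen or something else.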